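Trifluoromethoxy to methoxy exchange across two cores

The source may report more compounds than this note shows. Statements on the series, on what has been measured and on what is new or still open speak of the compounds shown alone.

Measured compounds in a functional assay on MCF7 cells (Homo sapiens) for antiproliferative activity, read by MTT assay; on this read-out lower numbers stand for stronger inhibition and higher numbers for weaker inhibition:
compound 1 `COc1ccc2nc(N(Cc3cc(-c4ccc(OC(F)(F)F)cc4)no3)c3nc4ccc(F)cc4s3)sc2c1`: 17400 nM
compound 2 `COc1ccc(-c2cc(CN(c3nc4ccc(F)cc4s3)c3nc4ccc(OC)cc4s3)on2)cc1`: 32400 nM
compound 3 `FC(F)(F)Oc1ccc(-c2cc(CN(c3ncccn3)c3nc4ccccc4s3)on2)cc1`: 14800 nM

All three numbers sit in a narrow band. Compound 1 and compound 2 share a core and differ only by methyl in place of trifluoromethyl on an oxygen on an aromatic ring; the step is a 1.9-fold higher number from compound 1 to compound 2 (0.27 log units; within the scatter). Compound 3 carries a different core; how the two cores differ is not broken down here, and of compound 1 and compound 3 only the two values themselves can be compared, which lie within the scatter of each other.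

Compound 4 `COc1ccc(-c2cc(CN(c3ncccn3)c3nc4ccccc4s3)on2)cc1` is not yet measured. It relates to compound 3 as compound 2 relates to compound 1: the change is methyl in place of trifluoromethyl on an oxygen on an aromatic ring, at the same place, so it is the same change seen once before. In this assay the expected step for compound 4 is a 1.6-fold higher number from compound 3 to compound 4 (0.21 log units; within the scatter), judged small because a 1.9-fold higher number from compound 1 to compound 2 (0.27 log units; within the scatter) was itself within the scatter. The estimate for compound 4 is therefore 24000 nM, expected to fall between 11000 nM and 55000 nM.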

Compound 4, half-maximal inhibitory concentration: 30700 nM
Beside the measured number, compound 4's estimate is 1.3-fold (0.11 log units) below it; the range from low to high includes it.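

In this assay, the exchange of trifluoromethoxy for methoxy on the core of compound 3 gives a 2.1-fold higher number from compound 3 to compound 4 (0.32 log units; beyond the scatter), a modest step. Set beside the earlier step, the same change has about the same size on both cores, and no difference between the cores can be read from the two steps: the same change on two cores in this assay, a 1.9-fold higher number (0.27 log units; within the scatter) from compound 1 to compound 2 and a 2.1-fold higher number (0.32 log units; beyond the scatter) from compound 3 to compound 4, 1.1-fold (0.05 log units) apart, within the scatter of two such steps This supports carrying the size of the step between these two cores only; it rests on two matched pairs in one assay, one step printed within the scatter and the other just beyond it, and it does not show that the step would hold on any further core.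

The compounds shown leave open how an amine, a carboxylic acid or a longer ether chain would read in place of trifluoromethoxy on the same aromatic ring. Also open, as far as these compounds go, is what each part of the core contributes, as compound 1 and compound 3 differ in more than one place.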